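Second Chloro on the Aryl Ring of Compound 2

The compounds below may be only part of what the source reports. "The series", "measured", "known", "first", "only" and "open" are said of these compounds alone.

Compound 1 `N#C/C(=C\N1CCN(C(=O)c2ccco2)C1=S)C(=O)Nc1ccc(Cl)cc1`: 15900 nM
Compound 2 `O=CN1CCN(c2ccc(Cl)cc2)C1=S`: 15700 nM

In a functional assay on DU-145 cells (Homo sapiens) for inhibition, read by sulforhodamine B assay, with a stated time of 48 h (a lower number here means a stronger inhibitor of growth, a higher number a weaker inhibitor of growth), compound 1 gives 15900 nM, and compound 2 gives 15700 nM. Compound 2 holds the lower of the two numbers, yet the gap to compound 1 lies within the scatter, so the two cannot be ranked.

Compound 3 `O=CN1CCN(c2ccc(Cl)c(Cl)c2)C1=S` differs from compound 2 by chloro in place of hydrogen on an aromatic carbon. Among the measured compounds shown here, no measured pair shows what this change does here, so only a small step is expected, probably no larger than the scatter in either direction. The resulting step of a 1.3-fold lower number from compound 2 to compound 3 (0.12 log units; within the scatter) is expected to stay small. Compound 3 is thus expected to give about 12000 nM, within 4000 nM to 40000 nM.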

Compound 3, concentration for 50% growth inhibition: 15700 nM
Compound 3: the middle estimate sits 1.3-fold (0.12 log units) below what was measured, within the range that was stated.
By their numbers in this assay, from the lowest: compounds 2, 3 and 1 (each within the scatter of the next).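

In this assay, putting chloro in place of hydrogen on this aromatic carbon, ortho to a chloro group, gives no change at the digits printed from compound 2 to compound 3 (within the scatter). Among the compounds shown here, this is the first measured pair for this change, and it shows that a second chloro at this position leaves the growth-inhibition number within the scatter. No measurement shown here offers an explanation for this result.

As far as these compounds go, whether a different group on this carbon, such as an amine or a carboxylic acid, moves the number remains open. A single pair also leaves open how chloro behaves on the other carbons of the ring.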